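The compounds below may be only part of what the source reports. "The series", "measured", "known", "first", "only" and "open" are said of these compounds alone.

Measured so far in an in vitro ADME assay on microsomes from liver (Rattus norvegicus) for metabolic stability; a lower number here means slower removal, a higher number faster removal of the compound
Compound 1 `CC(C)NC(=O)[C@H]1CC[C@@H](n2/c(=N/C(=O)c3ccc(F)cc3)[nH]c3ccc(CN4CC(C(C)(C)O)C4)cc32)CC1` gives < 14 mL.min-1.g-1 as a limit of the assay
Compound 2 `CC(C)NC(=O)[C@H]1CC[C@@H](n2/c(=N/C(=O)c3ccncc3)[nH]c3ccc(CN4CCC(C(C)(C)O)CC4)cc32)CC1` gives < 14 mL.min-1.g-1 as a limit of the assay

On these numbers compound 1 stands at the limit of < 14 mL.min-1.g-1 in this assay, at which 2 of the 2 values shown sit, and no exact value is available for it. Compound 3 `CC(C)NC(=O)[C@H]1CC[C@@H](n2/c(=N/C(=O)c3ccc(F)cc3)[nH]c3ccc(CN4CCNC(=O)C4)cc32)CC1` has not yet been measured. It carries 3-oxopiperazin-1-yl in place of 3-(1-hydroxy-1-methylethyl)azetidin-1-yl on a saturated chain carbon bound to an aromatic carbon. The counted difference is 3-oxopiperazin-1-yl in place of 3-(1-hydroxy-1-methylethyl)azetidin-1-yl on a saturated chain carbon bound to an aromatic carbon, and the rest of compound 1 is kept.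

Among the compounds with values here, no measured step is available for this change, and only two limits are at hand. In this assay a step within the scatter is therefore expected, with no firm direction. This expectation is supported by compound 2 with its own limit of < 14 mL.min-1.g-1 in this series. Another reported limit is the likeliest outcome for compound 3. The expected size of the step is a step that the limit leaves unreadable from compound 1 to compound 3, an estimate anchored on a limit. For compound 3 the expected value is 12 mL.min-1.g-1, with an estimated range of 7 mL.min-1.g-1 to 26 mL.min-1.g-1 in this read-out.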

Compound 3, intrinsic clearance in microsomes: 45 mL.min-1.g-1
For compound 3 the middle estimate is 3.8-fold (0.57 log units) below the measured one; measured number outside the range, above it.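

In this assay, the place on a saturated chain carbon bound to an aromatic carbon proves able to move the read-out: 3-oxopiperazin-1-yl in place of 3-(1-hydroxy-1-methylethyl)azetidin-1-yl gives an at least 3.2-fold higher number from compound 1 to compound 3 (0.50 log units; beyond the scatter). Compound 3 gives 45 mL.min-1.g-1, the first exact number in the series shown, and the two groups have the same counts of hydrogen-bond donors and acceptors, so those counts do not separate them. The step gives only a lower bound on the change, since compound 1 rests on a limit of the assay: the limit of < 14 mL.min-1.g-1 in this assay, at which 2 of the 3 values shown sit.

Ring size, the second ring nitrogen, the ring carbonyl and the loss of the 1-hydroxy-1-methylethyl group all change together here, so the feature that carries the step cannot be told apart. From the compounds shown here alone, a plain piperazin-1-yl or a morpholin-4-yl at this place would show whether the ring carbonyl or the ring itself goes with the higher number, and how far the 1-hydroxy-1-methylethyl group matters remains open.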